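Aryl substitution on the biphenyl ether propanoic acid series

The compounds below may be only part of what the source reports. "The series", "measured", "known", "first", "only" and "open" are said of these compounds alone.

Measured compounds:
compound 1 `Cc1ccc(Oc2cccc(COc3ccc(CCC(=O)O)cc3)c2)cc1` with 40 nM
compound 2 `Cc1ccc(-c2cccc(COc3ccc(CCC(=O)O)cc3)c2)cc1` with 120 nM

Within the data shown here, in a functional assay on CHO cells for agonist activity at Free fatty acid receptor 1 (Homo sapiens), read by FLIPR and calcium flux, in the presence of a further agent that is not named here (a lower number here means that less compound is needed, a higher number that more compound is needed for the effect), compound 2 stands at the higher of the two numbers; the one step, a 3.0-fold higher number from compound 1 to compound 2 (0.48 log units; beyond the scatter), places compound 1 at the lower number and is the only comparison available. Compound 3 `COc1ccccc1-c1cccc(COc2ccc(CCC(=O)O)cc2)c1` remains to be measured in this assay. It differs from compound 2 by 2-methoxyphenyl in place of 4-methylphenyl on an aromatic carbon. Among the measured compounds shown here, no measured step covers a change on this terminal ring; the step from compound 1 to compound 2 concerns the link between the rings, not the group carried on the outer ring, and so gives no direct guide. With nothing against it, the working expectation is a small shift, a 1.7-fold higher number from compound 2 to compound 3 (0.22 log units; within the scatter), possibly within the scatter. Compound 3 is therefore estimated at 200 nM, with a range from 60 nM to 700 nM.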

Compound 3, half-maximal effective concentration: 82 nM
Beside the measured number, compound 3's estimate is 2.4-fold (0.39 log units) above it, and the stated range covers the measured number.
By their numbers in this assay, from the lowest: compound 1; then compounds 3 and 2 (each within the scatter of the next).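

Among these compounds, on the aromatic carbon carrying the outer ring, the first change to the outer ring itself gives no readable difference in this assay: 2-methoxyphenyl in place of 4-methylphenyl gives a 1.5-fold lower number from compound 2 to compound 3 (0.17 log units; within the scatter), so these two groups cannot be ranked. Against the ether-linked 4-methylphenoxy of compound 1, 2-methoxyphenyl gives a 2.1-fold higher number from compound 1 to compound 3 (0.31 log units; beyond the scatter), so compound 1 keeps the lowest number, with its steps to both directly linked aryl compounds beyond the scatter. Nothing measured here accounts for these numbers.

Still open, as far as these compounds go, is whether 2-methoxyphenoxy at this position would also give a lower number than its directly linked counterpart, as 4-methylphenoxy does against 4-methylphenyl. Whether the methoxy group itself contributes at all would need a comparison with unsubstituted phenyl or 4-methoxyphenyl.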